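Swapping the Phenyl Group on the Ring Nitrogen

The source may hold more compounds than are shown below. What is called first, only, known or untested is meant among the compounds shown, and "the series" means these compounds.

Compound 2 `C/C(=C\CC/C(C)=C/CC[C@@H]1[C@@]2(C)CCC(=O)C(C)(C)[C@H]2CC[C@@]1(C)O)CC/C=C(\C)C(=O)OCc1cn(-c2cccc(O)c2)nn1` is the only one of the three measured compounds to give a number in a functional assay on A549 cells (Homo sapiens) for antiproliferative activity, read by MTT assay, with a stated time of 48 h (on this read-out lower numbers stand for stronger inhibition and higher numbers for weaker inhibition), rather than a limit: compound 2 gives 42800 nM. Compound 1 `C/C(=C\CC/C(C)=C/CC[C@@H]1[C@@]2(C)CCC(=O)C(C)(C)[C@H]2CC[C@@]1(C)O)CC/C=C(\C)C(=O)OCc1cn(-c2ccccc2Cl)nn1` reaches only the assay limit, giving > 150000 nM. Compound 3 `C/C(=C\CC/C(C)=C/CC[C@@H]1[C@@]2(C)CCC(=O)C(C)(C)[C@H]2CC[C@@]1(C)O)CC/C=C(\C)C(=O)OCc1cn(-c2ccc(F)c(Cl)c2)nn1` likewise stops at the limit, giving > 150000 nM. Compound 4 `C/C(=C\CC/C(C)=C/CC[C@@H]1[C@@]2(C)CCC(=O)C(C)(C)[C@H]2CC[C@@]1(C)O)CC/C=C(\C)C(=O)OCc1cn(-c2ccccc2Br)nn1` is not yet measured; it differs from compound 2 by 2-bromophenyl in place of 3-hydroxyphenyl on an aromatic nitrogen. The closest measured step runs the other way, an at least 3.5-fold lower number from compound 1 to compound 2 (0.54 log units; beyond the scatter), and compound 4 carries a 2-bromophenyl much like the 2-chlorophenyl of compound 1, so the swap is expected to raise the number, probably back to the limit (the limit of > 150000 nM in this assay, at which 2 of the 3 values shown sit). Compound 4 is therefore estimated at 150000 nM (60000 nM to 300000 nM), an expected step of a 3.5-fold higher number from compound 2 to compound 4 (0.54 log units; beyond the scatter).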

Compound 4, half-maximal inhibitory concentration: > 150000 nM
Compound 4 ended at the assay's limit (the forecaster's own chance of this, stated with the estimate: 70%); the middle value lies on the limit itself.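

In this assay, 2-bromophenyl in place of 3-hydroxyphenyl gives an at least 3.5-fold higher number from compound 2 to compound 4 (0.54 log units; beyond the scatter). With a third halogen-bearing phenyl group failing to give a number, 3-hydroxyphenyl remains the only group of the four on this ring nitrogen to do so, and no compound shown goes against this. The steps among compounds 1, 3 and 4 cannot be read, since each value is only a limit: the limit of > 150000 nM in this assay, at which 3 of the 4 values shown sit.

As far as these compounds go, it stays open whether the hydroxyl group itself matters or only the loss of the halogens. A 3-methoxyphenyl, 3-aminophenyl or unsubstituted phenyl group on the same nitrogen would help to separate these.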